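Methyl in place of pyridin-2-yl: compound 2 to compound 4

This account rests on a few compounds, and the source may have more. Where it says the series, first, only, none or still open, it means among the compounds named here.

Measured in a functional assay on MDA-MB-231 cells (Homo sapiens) for cytotoxicity, read by MTT assay, with a stated time of 48 h; on this read-out lower numbers stand for stronger inhibition and higher numbers for weaker inhibition:
- compound 1 `COc1cc(/C=C2\C(=O)Nc3ccccc32)ccc1OCCCN1CCN(c2ccccn2)CC1`: > 20000 nM
- compound 2 `COc1cc(/C=C2\C(=O)Nc3ccc(Cl)cc32)ccc1OCCCN1CCN(c2ccccn2)CC1`: 14800 nM
- compound 3 `COc1cc(/C=C2\C(=O)Nc3ccc(C)cc32)ccc1OCCCN1CCN(c2ncccc2C(F)(F)F)CC1`: > 20000 nM

Compound 1 gives > 20000 nM, which is a limit and not a number. Compound 3 gives > 20000 nM, which is also a limit. Among the compounds with values here, compound 2, at 14800 nM, holds the only actual number in the set.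

The next change leads to compound 4 `COc1cc(/C=C2\C(=O)Nc3ccc(Cl)cc32)ccc1OCCCN1CCN(C)CC1`: methyl in place of pyridin-2-yl on an amine nitrogen in a ring. Within the data shown here, the one measured step, an at least 1.3-fold lower number from compound 1 to compound 2 (0.13 log units; that floor lies within the scatter), is chloro in place of hydrogen on an aromatic carbon, so it concerns a different change, and its floor lies within the scatter. Among the measured compounds shown here, no measured step covers the group now exchanged. The data end at the limit of > 20000 nM in this assay, at which 2 of the 3 values shown sit, so a limit is also a likely result here.

No step beyond the scatter is therefore expected in this assay, in either direction, and the expectation stays anchored on compound 2 at 14800 nM. The expected change is a 1.1-fold higher number from compound 2 to compound 4 (0.03 log units; within the scatter). For compound 4 the estimate is 16000 nM, with an expected range of 7000 nM to 30000 nM.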

Compound 4, half-maximal inhibitory concentration: 1750 nM
For compound 4 the middle estimate is 9.1-fold (0.96 log units) above the measured one; measured number below the stated range.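

In this assay, the step from pyridin-2-yl to methyl on the amine nitrogen in the ring gives an 8.5-fold lower number from compound 2 to compound 4 (0.93 log units; beyond the scatter). This shows that the read-out responds to the group at this position, and that the pyridin-2-yl ring is not required for activity in this pair, with the much smaller methyl giving the lower number. Compound 1 and compound 3 carry limits and not numbers, so this pair gives the only quantified reading of this position: the limit of > 20000 nM in this assay, at which 2 of the 4 values shown sit.

From the compounds shown here alone, whether the gain is specific to methyl remains open, as hydrogen, ethyl, or an acetyl group on the same nitrogen would be needed to show how it varies with the group. Going by these compounds, the step is also read only on the chloro-bearing core of compound 2, so its transfer to the unsubstituted core of compound 1 remains unknown.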